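The source may report more compounds than this note shows. Statements on the series, on what has been measured and on what is new or still open speak of the compounds shown alone.

Series in a functional assay on the whole organism (strain Sprague-Dawley) for inhibition, with Rattus norvegicus as the target, with a stated time of 10 min; a higher number here means that more compound is needed for the effect, a lower number that less compound is needed:
- compound 1 `CCOC(=O)c1cnc(-c2cc(Cl)ccc2OCC)[nH]c1=O`: 0.5 mg/kg
- compound 2 `CCOC(=O)c1cnc(-c2cc(S(=O)(=O)Cl)ccc2OCC)[nH]c1=O`: "not determined" (no result reported)
- compound 3 `CCOC(=O)c1cnc(-c2cc(S(=O)(=O)N(C)C)ccc2OCC)[nH]c1=O`: 50 mg/kg

Compound 3 carries the higher of the two numbers available, and its nearest neighbour is compound 1 at 0.5 mg/kg. Compound 2 adds no number to this comparison.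

The next entry is compound 4 `CCOC(=O)c1cnc(-c2cc(S(=O)(=O)N(C)C(C)C)ccc2OCC)[nH]c1=O`, still unmeasured. It differs from compound 3 by isopropyl in place of methyl on a sulfonamide nitrogen.

Within the data shown here, only one measured step is available: a 100-fold higher number from compound 1 to compound 3 (2.00 log units; beyond the scatter). This step is large and beyond the scatter, but it concerns dimethylsulfamoyl in place of chloro on an aromatic carbon. Among the measured compounds shown here, compound 4 keeps the sulfonamide, so the change under consideration lies within that group, and no measured step covers a change on the sulfonamide nitrogen. The size of the step from chloro therefore cannot be carried over, and the data give no direction for the new change. With no evidence for a shift in this assay, no step beyond the scatter is expected.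

The expected change is no change at the digits printed from compound 3 to compound 4 (within the scatter). For compound 4 the estimate is 50 mg/kg, with an expected range from 15 mg/kg to 170 mg/kg.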

Compound 4, dose for 50% inhibition: > 10 mg/kg
Compound 4 was reported as a limit (the forecaster's own chance of this, stated with the estimate: 25%); the middle value is on the limit's open side.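

For compound 4 the entry in this assay is a limit and not a number: the limit of > 10 mg/kg in this assay, at which 1 of the 4 values shown sits.

Even so, the comparison with the chloro compound can be read, with an at least 20-fold higher number from compound 1 to compound 4 (1.30 log units; beyond the scatter), and this sits beside a 100-fold higher number from compound 1 to compound 3 (2.00 log units; beyond the scatter). The large step away from chloro on this aromatic carbon therefore holds for two sulfonamides, isopropyl(methyl)sulfamoyl as well as dimethylsulfamoyl, and is no longer tied to a single group. The step from compound 3 to compound 4 cannot be read, so isopropyl in place of methyl on a sulfonamide nitrogen has neither a size nor a direction in this series.

Open, on these data alone, is whether any group on the sulfonamide nitrogen, such as a longer chain, a chain ending in an amine or a chain ending in a carboxylic acid, would bring the number back towards that of compound 1 at 0.5 mg/kg. Also open is whether a sulfonamide with two hydrogens on its nitrogen would follow the two sulfonamides shown or stand closer to the chloro compound.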